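The source may report more compounds than this note shows. Statements on the series, on what has been measured and on what is new or still open speak of the compounds shown alone.

Three compounds have been measured in a functional assay on PC-12 cells (Rattus norvegicus) for cytotoxicity, read by MTT assay, with stated times of 3 h and 2 h, tested at 1 uM; a higher number here means a stronger effect of the compound at the concentration tested, a lower number a weaker effect:
compound 1 `COc1ccc(-c2cc3ccc(OCCCn4cc(CNC(=O)CCCCC5CCSS5)nn4)cc3oc2=O)cc1`, 47.4%;
compound 2 `O=C(CCCCC1CCSS1)NCc1cn(CCCOc2ccc3cc(-c4ccc(Cl)cc4)c(=O)oc3c2)nn1`, 49.3%;
compound 3 `O=C(CCCCC1CCSS1)NCc1cn(CCCCOc2ccc3ccc(=O)oc3c2)nn1`, 45.9%.

Compound 3 gives the lowest of the three numbers, but the two other numbers sit within the usual scatter of it, so the three compounds cannot be told apart on this read-out. Among the measured compounds shown here, the only pair that differs in a single place is compound 1 and compound 2, where a number 1.9 percentage points higher from compound 1 to compound 2 (within the scatter), an exchange of one small substituent for another that left the read-out essentially unchanged.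

Compound 4 `O=C(CCCCC1CCSS1)NCc1cn(CCCCOc2ccc3cc(-c4ccccc4)c(=O)oc3c2)nn1` is the next compound to be measured. It differs from compound 3 by phenyl in place of hydrogen on an aromatic carbon. For the measured compounds named here, no measured step exchanges hydrogen for phenyl at this place, so none bears directly on it. Compounds 1 and 2 each carry a substituted phenyl ring where compound 3 carries hydrogen, and compound 1 with 47.4% and compound 2 with 49.3% lie alongside compound 3, which is consistent with a ring at this place changing little here. The step from compound 3 to compound 4 in this assay is therefore expected to be small, a number 2.1 percentage points higher from compound 3 to compound 4 (within the scatter), with no direction beyond the scatter. Compound 4 is estimated at 48%, in a range from 38% to 58%.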

Compound 4, a percentage reported as activity, at one concentration (the size of the read-out at that concentration, not a potency): 34.8%
The estimate for compound 4 lay 13.2 percentage points above the measured number; measured number outside the range, below it.
By their numbers in this assay, from the lowest: compound 4; then compounds 3, 1 and 2 (each within the scatter of the next).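

In this assay, phenyl in place of hydrogen on the aromatic carbon two atoms from the ring oxygen gives a number 11.1 percentage points lower from compound 3 to compound 4 (beyond the scatter), the first step among these compounds to lie beyond the scatter and a sign that this position is not indifferent to a ring, at least with the chain of compound 3. Compounds 1 and 2 could not show this: each carries a substituted phenyl ring at this place but also a different chain, so neither differs from compound 3 in one place only, and the exchange between them concerns only a substituent on that ring. Nothing measured here gives a reason for the step from hydrogen to phenyl.

The compounds shown leave open whether the same exchange on the chain of compounds 1 and 2 would give a step of similar size, as no pair tests hydrogen against a ring on that chain. From the compounds shown here alone, they also leave open how a much smaller group at this place, such as methyl, or a phenyl ring carrying an amine would read out, so it remains unknown whether the size of the group or the ring itself goes with the change.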